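A Methoxy Group Enters Where Nothing Has Yet Moved

The compounds below may be only part of what the source reports. "The series", "measured", "known", "first", "only" and "open" are said of these compounds alone.

Compound 1 `CC(C)(C)Cc1csc(N)c1C(=O)c1cccc(Cl)c1` was tested in an assay on CHO cells for displacement of a labelled ligand from adenosine receptor A1 (Homo sapiens), read by scintillation counting, tested at 10 uM (on this read-out higher numbers stand for more inhibition at the one concentration tested (going by the name of the read-out) and lower numbers for less inhibition), where compound 1 gives 2%. Compound 2 `CC(C)(C)Cc1c(-c2ccccc2)sc(N)c1C(=O)c1cccc(Cl)c1` carries a phenyl in place of hydrogen on an aromatic carbon, and in this assay compound 2 gives 2%. The step of no change at the digits printed from compound 1 to compound 2 (within the scatter) shows that adding the phenyl left the read-out unchanged, so compound 2 stands level with compound 1, both near the bottom of the scale at the single concentration tested.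

Compound 3 `COc1ccc(-c2sc(N)c(C(=O)c3cccc(Cl)c3)c2CC(C)(C)C)cc1` has not yet been measured. It differs from compound 2 in one place: methoxy in place of hydrogen on an aromatic carbon. Among the measured compounds shown here, the only measured step, no change at the digits printed from compound 1 to compound 2 (within the scatter), was flat, and no measured step involves a methoxy group, so the data offer no reason to expect a move in either direction beyond the scatter. The step expected from compound 2 to compound 3 is therefore a number 3 percentage points higher from compound 2 to compound 3 (within the scatter). Compound 3 is estimated at 5%, in a range from 0% to 20%.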

Compound 3, a percentage reported as inhibition, at one concentration (the size of the read-out at that concentration, not a potency): 1%
Estimate against measurement, compound 3: 4 percentage points above; the range from low to high includes it.
By their numbers in this assay, from the lowest: compounds 3, 1 and 2 (each within the scatter of the next).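

In this assay methoxy on the six-membered aromatic ring, para to a large group, gives a number 1 percentage points lower from compound 2 to compound 3 (within the scatter) and so extends the flat picture: this position has now carried a second, larger group with the read-out still inside the scatter. Measured against the unsubstituted starting point, 4-methoxyphenyl in place of hydrogen gives a number 1 percentage points lower from compound 1 to compound 3 (within the scatter) and stands level with compound 1 as well. Nothing measured here explains why these values stay together near the bottom of the scale.

Going by these compounds, all three compounds sit this low at a single concentration, so it remains open whether any group at this position can raise the inhibition at all. An amine or a carboxylic acid on the phenyl, or a longer chain in place of the methoxy, would put that question to a sharper test.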